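Anilide ring substitution: from 4-methylphenyl to 2-methoxyphenyl

The compounds below may be only part of what the source reports. "The series", "measured", "known", "first", "only" and "open" are said of these compounds alone.

Among the compounds with values here, compound 1 `COc1ccc2c(=O)c(/C=C/C(=O)Nc3ccc(C)cc3)coc2c1` gives 979000 nM in an ADME assay on HepG2 2.2.15 cells (Homo sapiens) for cytotoxicity, read by MTT assay, with stated times of 48 h and 9 days (a higher number here means that more compound is tolerated, a lower number that less compound is tolerated), the highest of the three numbers so far; compound 3 `COc1ccc2c(=O)c(/C=C/C(=O)NCc3ccccc3)coc2c1` gives 376000 nM and compound 2 `COc1ccc2c(=O)c(/C=C/C(=O)NCc3ccc(F)cc3)coc2c1` gives 133000 nM. Compound 4 `COc1ccc2c(=O)c(/C=C/C(=O)Nc3ccccc3OC)coc2c1` differs from compound 1 by 2-methoxyphenyl in place of 4-methylphenyl on an amide-type nitrogen. Within the data shown here, no measured step swaps one ring substituent for another on an aryl amide; a 7.4-fold lower number from compound 1 to compound 2 (0.87 log units; beyond the scatter) and a 2.6-fold lower number from compound 1 to compound 3 (0.42 log units; beyond the scatter) both exchange the aryl for a benzyl, while a 2.8-fold higher number from compound 2 to compound 3 (0.45 log units; beyond the scatter) is the only substituent-only step and is modest. A modest change, if any, is therefore expected, direction uncertain but leaning lower. The expected step is about a 1.6-fold lower number from compound 1 to compound 4 (0.21 log units; within the scatter). Compound 4 is estimated at 600000 nM, within 200000 nM to 1500000 nM.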

Compound 4, half-maximal cytotoxic concentration: 1050000 nM
Estimate against measurement, compound 4: 1.8-fold (0.24 log units) below, within the range that was stated.
By their numbers in this assay, from the lowest: compound 2; then compound 3; then compounds 1 and 4 (each within the scatter of the next).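

In this assay a change of substituent on the aryl ring of the amide can now be read directly: a 1.1-fold higher number from compound 1 to compound 4 (0.03 log units; within the scatter) leaves 2-methoxyphenyl and 4-methylphenyl indistinguishable. With a 2.8-fold higher number from compound 3 to compound 4 (0.45 log units; beyond the scatter) and a 7.9-fold higher number from compound 2 to compound 4 (0.90 log units; beyond the scatter) as well, both aryl amides stand apart from both benzyl amides, so the separation seen with 4-methylphenyl also holds with 2-methoxyphenyl.

Going by these compounds, whether an amine or a carboxylic acid on the aryl ring would keep the number at this level remains open, as does the effect of a phenethyl group on the amide-type nitrogen. Nothing at hand explains these differences.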